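The source may hold more compounds than are shown below. What is called first, only, known or untested is meant among the compounds shown, and "the series" means these compounds.

Notes on a small series built on a shared core. Compound 1 `N#CC1=C(N)Oc2c(c3nc4ccccc4nc3c3ccccc23)C12C(=O)N(Cc1cnnn1-c1ccc([N+](=O)[O-])cc1)c1ccccc12` returns only a limit in a functional assay on MCF7 cells (Homo sapiens) for antiproliferative activity, read by MTT assay, with a stated time of 48 h; a higher number here means a weaker inhibitor, a lower number a stronger inhibitor: compound 1 gives > 50000 nM, which is a limit of the assay and not a number. Compound 2 `N#CC1=C(N)Oc2c(N)cc3nc4ccccc4nc3c2C12C(=O)N(Cc1cnnn1-c1cccc(Br)c1)c1ccccc12` likewise returns a limit in this assay, where compound 2 gives > 50000 nM. Compound 2 thus stands at the limit shared by both values shown (the limit of > 50000 nM in this assay, at which 2 of the 2 values shown sit), so no ordering between compound 1 and compound 2 can be read from the numbers. Compound 3 `N#CC1=C(N)Oc2c(N)cc3nc4ccccc4nc3c2C12C(=O)N(Cc1cnnn1-c1ccc(F)c(Cl)c1)c1ccccc12` is not yet measured in this assay. It differs from compound 2 in one place (3-chloro-4-fluorophenyl in place of 3-bromophenyl on an aromatic nitrogen). Among the compounds with values here, no measured step of this kind is in hand, so the expectation rests only on where compound 2 sits. The step meant by the estimate for compound 3 is expected to be a number no higher from compound 2 to compound 3 (the limit leaves the size open), none beyond the scatter, most likely another limit. Compound 3 is expected to give 50000 nM in this assay, with a range from 20000 nM to 120000 nM.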

Compound 3, half-maximal inhibitory concentration: 17800 nM
Compound 3: the middle estimate sits 2.8-fold (0.45 log units) above what was measured; measured number below the stated range.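

In this assay, within the data shown here, 3-chloro-4-fluorophenyl in place of 3-bromophenyl on the aromatic nitrogen gives an at least 2.8-fold lower number from compound 2 to compound 3 (0.44 log units; beyond the scatter), the first step that can be read. This position therefore responds to the choice of aryl group, and a change here alone is enough to bring the shared core from the limit to a measured value. The size of the step has only a lower bound, because one end of it is a limit of the assay and not a number: the limit of > 50000 nM in this assay, at which 2 of the 3 values shown sit.

Among these compounds, the single step changes the halogens and their places together, so it cannot assign the shift to the chlorine, the fluorine or the loss of the bromine. Among the compounds shown here, how a plain phenyl, a benzyl group or a longer alkyl chain would read at this position stays open, and no step to compound 1 can be read.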